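Methyl on a Compound Resting at the Assay Limit

The compounds below may be only part of what the source reports. "The series", "measured", "known", "first", "only" and "open" are said of these compounds alone.

Compound 2 (`CCn1c(/C=C2/C(=O)Nc3ccccc32)nc2ccccc21`) is measured in a functional assay on 4T1 cells (Homo sapiens) for cytotoxicity, read by MTT assay, with a stated time of 48 h (on this read-out higher numbers stand for weaker inhibition and lower numbers for stronger inhibition), and gives > 50000 nM as its result, which is a limit and not a number. Compound 2 thus stands at the limit of > 50000 nM in this assay, at which 2 of the 3 values shown sit, and has no exact value. Compound 1 (`CCn1c(/C=C2/C(=O)Nc3ccc(F)cc32)nc2ccccc21`) gives > 50000 nM as its result, also a limit. Compound 3 (`CC(C)n1c(/C=C2/C(=O)Nc3ccccc32)nc2ccccc21`) gives 40400 nM in this assay and is the only one of the three with a measured number.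

The change to compound 4 (`CCn1c(/C=C2/C(=O)Nc3ccc(C)cc32)nc2ccccc21`) is methyl in place of hydrogen on an aromatic carbon. Going by the values given here, the one measured change on an aromatic carbon, hydrogen in place of fluoro, is (a step that the two limits leave unreadable from compound 1 to compound 2) and offers no size to build on. The other measured change, methyl in place of hydrogen on a saturated chain carbon, is (an at least 1.2-fold lower number from compound 2 to compound 3 (0.09 log units; that floor lies within the scatter)) and its floor stays within the scatter.

Neither step points to a large move, so at most a small shift to a lower number is expected in this assay. The estimated result is an at least 1.1-fold lower number from compound 2 to compound 4 (0.04 log units; that floor lies within the scatter) and it is expected to stay within the scatter. For compound 4 the expected value is 45000 nM with an estimated range from 22000 nM to 90000 nM in this estimate. A report of only a limit is about as likely.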

Compound 4, half-maximal inhibitory concentration: 39400 nM
Estimate against measurement, compound 4: 1.1-fold (0.06 log units) above; the range from low to high includes it.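

Methyl in place of hydrogen on this aromatic carbon, para to a fused ring and meta to a fused ring, gives the first step at this position with a readable floor in this assay, namely an at least 1.2-fold lower number from compound 2 to compound 4 (0.10 log units; that floor lies within the scatter). Methyl in place of fluoro on the same carbon gives a second such floor, an at least 1.2-fold lower number from compound 1 to compound 4 (0.10 log units; that floor lies within the scatter), while the step between the fluoro and hydrogen compounds still cannot be read, so both floors lie within the scatter and neither establishes a real change on its own. The true size of either step remains unknown because compound 1 and compound 2 supply only limits as starting points, not numbers: the limit of > 50000 nM in this assay, at which 2 of the 4 values shown sit.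

The compounds shown leave open how an amine, a methoxy group or a carboxylic acid on this aromatic carbon would read in this assay, and whether any group here can bring the number clearly beyond the scatter. They also leave open whether methyl on this aromatic carbon and the added methyl of compound 3 would combine in a single compound to give a larger step.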